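A few compounds are considered here, and "the series" means these few. Any claim that something is new, unique, unknown or untested is made for them only; others in the source may bear on it.

Measured compounds in a functional assay on CWR22R cells (Homo sapiens) for antiproliferative activity, read by CCK-8 assay, with a stated time of 6 days; a lower number here means a stronger inhibitor, a higher number a weaker inhibitor:

Compound 1, `CCN(c1ccc(C#N)c(Cl)c1)c1cc(-c2ccccc2)ccc1C`: > 30000 nM
Compound 2, `CCN(c1cccc(-c2ccccc2)c1)c1ccc(C#N)c(Cl)c1`: "not determined" (no result reported)
Compound 3, `N#Cc1ccc(N2CCc3cc(-c4cccnc4)ccc32)cc1C(F)(F)F`: "not determined" (no result reported).

For compound 1 the entry > 30000 nM is a limit of this assay and not a number. For compound 2 and compound 3 this assay gave no result at all. Compound 2 therefore stands nowhere on a scale of numbers: of the three entries in this assay, one is a limit of > 30000 nM in this assay, at which 1 of the 3 values shown sits, and the other two are empty, so no value can be put beside it or set against it.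

Compound 4, `CCN(c1cccc(-c2cncnc2)c1)c1ccc(C#N)c(Cl)c1`, is to be measured in this assay. It differs from compound 2 in one place: pyrimidin-5-yl in place of phenyl on an aromatic carbon. Within the data shown here, no step between measured compounds exists, so the size and direction of the change from compound 2 to compound 4 in this assay cannot be read from any measured pair. The expectation has to be framed loosely; the change may fall within the scatter or move the value in either direction.

Against this background, the value of compound 4 in this assay is estimated at 5000 nM, with an expected range from 300 nM to 30000 nM, and a fair chance that only a limit is reported.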

Compound 4, half-maximal inhibitory concentration: > 30000 nM
Compound 4: only a limit was reported (the forecaster's own chance of this, stated with the estimate: 35%); at least 6.0-fold (0.77 log units) between middle value and limit.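

In this assay compound 4 gives > 30000 nM, a limit of the assay and not a number. Among these compounds, compound 2 has no result in this assay, and no new step from compound 2 to compound 4 can be read. The compounds shown leave open whether pyrimidin-5-yl in place of phenyl changes activity at all, with limits the only entries so far: the limit of > 30000 nM in this assay, at which 2 of the 4 values shown sit.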